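A thiazolyl ketone in place of an azetidinyl amide

This account rests on a few compounds, and the source may have more. Where it says the series, first, only, none or still open, it means among the compounds named here.

Measured in a physicochemical assay for solubility, read by HPLC, with a stated time of 24 h; on this read-out lower numbers stand for lower solubility and higher numbers for higher solubility:
compound 1 `CC(C)(C)c1[nH]cnc1/C=c1\[nH]c(=O)/c(=C/c2cccc(C(=O)N3CCC3)c2)[nH]c1=O`: 4.23 ug/mL
compound 2 `O=C(c1cccc(/C=c2\[nH]c(=O)/c(=C/c3ccccn3)[nH]c2=O)c1)N1CCC1`: 0.662 ug/mL

Compound 1 holds the higher of the two numbers in this assay. Compound 3 `CC(C)(C)c1[nH]cnc1/C=c1\[nH]c(=O)/c(=C/c2cccc(C(=O)c3cncs3)c2)[nH]c1=O` differs from it by 1,3-thiazol-5-yl in place of azetidin-1-yl on a carbonyl carbon, with 1,3-thiazol-5-yl in place of azetidin-1-yl on a carbonyl carbon. No measurement covers this exchange. Among the compounds with values here, the only measured step, a 6.4-fold lower number from compound 1 to compound 2 (0.81 log units; beyond the scatter), lies beyond the scatter but sits at another place, so it shows only how far a single exchange can move the number. A modest fall is tentatively expected, a 2.6-fold lower number from compound 1 to compound 3 (0.42 log units; beyond the scatter). For compound 3 the estimated value is 1.6 ug/mL, with an expected range of 0.4 ug/mL to 5.5 ug/mL.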

Compound 3, solubility: < 0.1 ug/mL
Compound 3 was reported as a limit (the forecaster's own chance of this, stated with the estimate: 10%); at least 16-fold (1.20 log units) between middle value and limit.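

In this assay, the place on the carbonyl carbon turns out to matter at least as much as the place changed earlier: 1,3-thiazol-5-yl in place of azetidin-1-yl gives an at least 42-fold lower number from compound 1 to compound 3 (1.62 log units; beyond the scatter). The earlier step, a 6.4-fold lower number from compound 1 to compound 2 (0.81 log units; beyond the scatter), sat elsewhere and said nothing about this carbonyl carbon. The reading for compound 3 is a limit and not a number: the limit of < 0.1 ug/mL in this assay, at which 1 of the 3 values shown sits.

The compounds shown leave open whether the fall follows the loss of the azetidin-1-yl group or the entry of the 1,3-thiazol-5-yl ring. A phenyl ketone or a piperazinyl amide on the same carbonyl carbon would separate the two.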